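The source may report more compounds than this note shows. Statements on the series, on what has been measured and on what is new or still open speak of the compounds shown alone.

Measured so far in a functional assay on A549 cells (Homo sapiens) for antiproliferative activity, read by MTT assay (a lower number here means a stronger inhibitor, a higher number a weaker inhibitor), for this series
compound 1 `CC1(C)CCc2cc(C(=O)/C=C/c3ccc(OCc4cn(-c5ccc(Cl)cc5)nn4)cc3)c(O)cc2O1` gives 75500 nM as its result
compound 2 `CC1(C)CCc2cc(C(=O)/C=C/c3ccc(OCc4cn(-c5ccc(Br)cc5)nn4)cc3)c(O)cc2O1` gives 80000 nM as its result
compound 3 `Cc1c(-n2cc(COc3ccc(/C=C/C(=O)c4ccc5c(c4O)CCC(C)(C)O5)cc3)nn2)cccc1[N+](=O)[O-]` gives "not active" (no number reported) as its result

Among the compounds with values here, compound 3 is recorded as "not active" (no number reported) and carries no number, so no step can be counted from it. Compound 4 `CC1(C)CCc2c(ccc(C(=O)/C=C/c3ccc(OCc4cn(Cc5ccc([N+](=O)[O-])cc5)nn4)cc3)c2O)O1` comes from compound 3 by 4-nitrobenzyl in place of 2-methyl-3-nitrophenyl on an aromatic nitrogen with 4-nitrobenzyl in place of 2-methyl-3-nitrophenyl on an aromatic nitrogen.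

Within the data shown here, the only measured step is a 1.1-fold higher number from compound 1 to compound 2 (0.03 log units; within the scatter) and it concerns bromo in place of chloro on an aromatic carbon. Among the measured compounds shown here, it therefore bears only loosely on a change on the aromatic nitrogen, and no measured compound carries 4-nitrobenzyl. For the measured compounds named here, no step of definite size or direction can be expected from these data. The numbers available are high, with compound 1 at 75500 nM and compound 2 at 80000 nM in this assay, so compound 4 is expected to give a similarly high number, and a second result without a number remains quite possible. In this assay the half-maximal inhibitory concentration of compound 4 is estimated at 70000 nM within an expected range of 30000 nM to 150000 nM if a number is reported at all.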

Compound 4, half-maximal inhibitory concentration: 69900 nM
The estimate for compound 4 lay 1.0-fold (0.00 log units) above the measured number, and the stated range covers the measured number.
By their numbers in this assay, from the lowest: compounds 4, 1 and 2 (each within the scatter of the next).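

In this assay compound 4 gives 69900 nM while compound 3 is recorded as not active with no number, so no step can be read between them. No available evidence bears on this result. The compounds shown leave open how 4-nitrobenzyl and 2-methyl-3-nitrophenyl compare on the aromatic nitrogen when both carry a number.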